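Huh-7 inhibition series: sulfamoyl in place of an amine chain

The source may report more compounds than this note shows. Statements on the series, on what has been measured and on what is new or still open speak of the compounds shown alone.

compound 1 `C=CC(=O)Nc1cc(CCCN(C)C)cc(C)c1Nc1ncc2cc(-c3c(Cl)c(OC)cc(OC)c3Cl)ccc2n1` — 2240 nM
compound 2 `C=CC(=O)Nc1cc(S(=O)(=O)NC(=O)C=C)ccc1Nc1ncc2cc(-c3c(Cl)c(OC)cc(OC)c3Cl)ccc2n1` — 4750 nM

Both numbers come from a functional assay on Huh-7 cells (Homo sapiens) for inhibition, read by sulforhodamine B assay, with a stated time of 72 h; on this read-out lower numbers stand for stronger inhibition and higher numbers for weaker inhibition. Compound 1 gives 2240 nM and holds the lower of the two numbers; the number for compound 2 is higher, a gap beyond the scatter. Compound 3 `C=CC(=O)Nc1cc(S(N)(=O)=O)cc(C)c1Nc1ncc2cc(-c3c(Cl)c(OC)cc(OC)c3Cl)ccc2n1` is not yet measured. The change from compound 1 to compound 3 is sulfamoyl in place of 3-(dimethylamino)propyl on an aromatic carbon. Among the compounds with values here, no step between measured compounds covers this exchange alone. A modest rise is expected, a 1.6-fold higher number from compound 1 to compound 3 (0.19 log units; within the scatter), because compound 2 gives 4750 nM. Compound 3 is estimated at 3500 nM, within 1200 nM to 10000 nM.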

Compound 3, half-maximal inhibitory concentration: 1670 nM
Compound 3: middle estimate off by 2.1-fold (0.32 log units), on the high side, and the stated range covers the measured number.
By their numbers in this assay, from the lowest: compounds 3 and 1 (each within the scatter of the next); then compound 2.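

In this assay, sulfamoyl in place of 3-(dimethylamino)propyl on this aromatic carbon, meta to a methyl group, gives a 1.3-fold lower number from compound 1 to compound 3 (0.13 log units; within the scatter). This position therefore accepts two quite different groups with no change beyond the scatter, so the 3-(dimethylamino)propyl chain is not required for the number seen here. No measurement on hand explains this equivalence.

Still open, as far as these compounds go, is whether a carboxylic acid, a morpholine ring or a longer amine chain on this carbon would also stay within the scatter. Whether a hydrogen alone at this position would do the same is also unresolved.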